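The compounds below may be only part of what the source reports. "The series", "measured", "known", "first", "only" and "open" are said of these compounds alone.

Measured in an ADME assay (liver) for metabolic stability, with Liver microsome (Homo sapiens) as the target, using microsomes and NADPH, with a stated time of 30 min, tested at 1 uM; a higher number here means faster removal of the compound, a lower number slower removal:
- compound 1 `COc1cc(C(O)(C(F)(F)F)C(F)(F)F)cnc1N1CCN(S(=O)(=O)c2ccc(N)nc2)CC1`: < 14 mL.min-1.g-1, a limit of the assay and not a number
- compound 2 `Nc1ccc(S(=O)(=O)N2CCN(c3ncc(C(O)(C(F)(F)F)C(F)(F)F)cc3C3CC3)CC2)cn1`: 38 mL.min-1.g-1

Within the data shown here, compound 2 holds the only true number so far in this assay, at 38 mL.min-1.g-1. The next compound to read is compound 3 `Nc1ccc(S(=O)(=O)N2CCN(c3ncc(C(O)(C(F)(F)F)C(F)(F)F)cc3C#CCO)CC2)cn1`, and the change is 3-hydroxyprop-1-yn-1-yl in place of cyclopropyl on an aromatic carbon. In words, this is 3-hydroxyprop-1-yn-1-yl in place of cyclopropyl on an aromatic carbon, ortho to a large group.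

Among the measured compounds shown here, the one measured step at this carbon is an at least 2.7-fold higher number from compound 1 to compound 2 (0.43 log units; beyond the scatter), with cyclopropyl in place of methoxy on an aromatic carbon. It lies beyond the scatter. Here cyclopropyl leaves instead, so a move towards lower numbers is expected on that step alone. This is thin ground, since the entering group has no measurement of its own and a single step gives only a direction.

The expected step is downward and modest: a 1.9-fold lower number from compound 2 to compound 3 (0.28 log units; within the scatter). For compound 3 the estimated value in this assay is 20 mL.min-1.g-1, with an expected range of 10 mL.min-1.g-1 to 42 mL.min-1.g-1.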

Compound 3, intrinsic clearance in microsomes: < 14 mL.min-1.g-1
Compound 3: only a limit was reported; the forecaster's own chance of this, stated with the estimate: 35%; middle value at least 1.4-fold (0.15 log units) away from the limit.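

At the aromatic carbon ortho to a large group, a second replacement of cyclopropyl now exists in this assay: 3-hydroxyprop-1-yn-1-yl gives an at least 2.7-fold lower number from compound 2 to compound 3 (0.43 log units; beyond the scatter). Cyclopropyl therefore stands apart from both other groups shown at this carbon, since methoxy and 3-hydroxyprop-1-yn-1-yl each sit on the slower-removal side of compound 2, and the earlier pair alone could not show that this held for a group other than methoxy. The step between compound 1 and compound 3 cannot be read, and the two cannot be ordered, because both are reported only as a limit of the assay and not as a number: the limit of < 14 mL.min-1.g-1 in this assay, at which 2 of the 3 values shown sit.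

Going by these compounds, whether the lower read-out follows the hydroxyl or the triple bond stays open, and a prop-1-yn-1-yl group without the hydroxyl, or a saturated 3-hydroxypropyl chain, at this carbon would separate the two. Also open, on these data alone, is whether an amine or a carboxylic acid at the end of the chain would keep the read-out at the same limit, or whether a longer chain would bring back a true number.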